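The compounds below may be only part of what the source reports. "The series", "measured", "known", "first", "only" and "open" are said of these compounds alone.

In a functional assay on MCF7 cells (Homo sapiens) for cytotoxicity, read by MTT assay, with a stated time of 72 h (on this read-out higher numbers stand for weaker inhibition and lower numbers for stronger inhibition), two compounds of this series have been measured so far. Compound 1 `COc1ccc(-c2cc(/N=C3/NC(=O)CS3)cs2)cc1` gives > 50000 nM, which is a limit of the assay and not a number. For the measured compounds named here, compound 2 `COc1ccc(/C=C2\S/C(=N\c3csc(-c4ccc(Cl)cc4)c3)NC2=O)cc1` gives 1000 nM, and this is the only actual number in the set, so it stands alone as the reference point.

Compound 3 `O=C1N/C(=N/c2csc(-c3ccc(Cl)cc3)c2)S/C1=C\c1ccc(Br)cc1` retains the structure of compound 2 except for one group: bromo in place of methoxy on an aromatic carbon. This puts bromo in place of methoxy on an aromatic carbon, para to a large group, turning 4-methoxyphenyl into 4-bromophenyl.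

Going by the values given here, no two measured compounds differ in only one place, so no measured step shows what this exchange does. The expectation is therefore modest: no change beyond the usual scatter in this assay, and no firm direction. It rests solely on compound 2 at 1000 nM, and the range is kept wide to reflect that. The expected step is a 1.3-fold lower number from compound 2 to compound 3 (0.10 log units; within the scatter). Compound 3 is estimated at 800 nM, with an expected range from 200 nM to 3500 nM.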

Compound 3, half-maximal inhibitory concentration: 2500 nM
Estimate against measurement, compound 3: 3.1-fold (0.49 log units) below; the range from low to high includes it.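

In this assay the change from 4-methoxyphenyl to 4-bromophenyl gives the series its first measured step, which is a 2.5-fold higher number from compound 2 to compound 3 (0.40 log units; beyond the scatter) and shows that this place on the six-membered aromatic ring, para to a large group, responds to an exchange of a single group. On this read-out the higher number stands for weaker inhibition, so methoxy serves better here than bromo, although the step is modest and compound 3 stays in the same general range as compound 2. For the compounds shown here, nothing measured in this set gives a reason for the step, and the single pair cannot separate the loss of methoxy from the arrival of bromo.

The compounds shown leave open whether other groups at this same place, such as a hydroxyl, an amine, a carboxylic acid, a fluoro or a longer alkoxy chain, would fall on the side of methoxy or on that of bromo. They also leave open whether the same exchange would give a step of similar size and direction if the rest of the molecule were altered.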